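Pyrimidinyl for methoxyphenyl: expected cytotoxicity of compound 4

The compounds below may be only part of what the source reports. "The series", "measured", "known", "first", "only" and "open" are said of these compounds alone.

Compound 1, `COc1ccc(-n2c(=O)n(Cc3cc4cc(Cl)ccc4n3CCCC#N)c3cnccc32)cc1`: > 50000 nM
Compound 2, `CS(=O)(=O)CCCn1c(Cn2c(=O)n(C3CC3)c3ccncc32)cc2cc(Br)ccc21`: > 50000 nM
Compound 3, `CS(=O)(=O)CCCn1c(Cn2c(=O)n(C3CC3)c3ccncc32)cc2cc(F)ccc21`: > 50000 nM

In an ADME assay on HeLa cells (Homo sapiens) for cytotoxicity, read by ATP content, with a stated time of 3 days (on this read-out higher numbers stand for lower toxicity in this test and lower numbers for higher toxicity in this test), compound 1 gives > 50000 nM, which is a limit of the assay and not a number. Compound 2 likewise reaches only a limit, > 50000 nM. Compound 3 also stands at a limit, > 50000 nM. Within the data shown here, the single measured step, a step that the two limits leave unreadable from compound 2 to compound 3, cannot be read. Compound 4, `N#CCCCn1c(Cn2c(=O)n(-c3ncccn3)c3ccncc32)cc2cc(Cl)ccc21`, differs from compound 1 by pyrimidin-2-yl in place of 4-methoxyphenyl on an aromatic nitrogen. No measured step covers this change, and because of the limit of > 50000 nM in this assay, at which 3 of the 3 values shown sit, no size of effect can be read from the shown compounds. Compound 4 is expected to stay at the limit as well, an expected step that the limit leaves unreadable from compound 1 to compound 4. The estimate for compound 4 is 60000 nM, with a range from 25000 nM to 150000 nM.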

Compound 4, half-maximal cytotoxic concentration: > 50000 nM
Compound 4: a limit, no number; the forecaster's own chance of this, stated with the estimate: 80%; the middle value lies beyond the limit too.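

No step can be read from compound 1 to compound 4, because both values are limits and not numbers: the limit of > 50000 nM in this assay, at which 4 of the 4 values shown sit.

The compounds shown leave open whether pyrimidin-2-yl in place of 4-methoxyphenyl changes the half-maximal cytotoxic concentration at all.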